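The source may hold more compounds than are shown below. What is called first, only, known or untested is meant among the compounds shown, and "the series" means these compounds.

Compound 1, `COc1ccc(S(=O)(=O)N(Cc2cc(C)on2)[C@H](C)C(=O)NO)cc1`, gives 230 nM in an assay on isolated protein for inhibition of bone morphogenetic protein 1 (Homo sapiens); a lower number here means a stronger inhibitor, a higher number a weaker inhibitor.
Compound 2, `COc1ccc(S(=O)(=O)N(Cc2ccc(Cl)c(Cl)c2)[C@H](C)C(=O)NO)cc1`, gives 120 nM in this assay.

Compound 2 holds the lowest of the two numbers shown, though its gap to compound 1, a 1.9-fold lower number from compound 1 to compound 2 (0.28 log units; within the scatter), lies within the scatter. Compound 3, `COc1ccc(S(=O)(=O)N(Cc2cnc(Cl)s2)[C@H](C)C(=O)NO)cc1`, differs from compound 2 in one place: 2-chloro-1,3-thiazol-5-yl in place of 3,4-dichlorophenyl on a saturated chain carbon bound to a sulfonamide nitrogen. Going by the values given here, one measured step bears on this position, the exchange of the ring on that carbon between compound 1 and compound 2, a 1.9-fold lower number from compound 1 to compound 2 (0.28 log units; within the scatter), and it stayed within the scatter. A second ring exchange at the same place is therefore expected to shift this assay little, with no direction beyond the scatter foreseen. Compound 3 is estimated at 180 nM, with a range from 80 nM to 400 nM. The expected step is a 1.5-fold higher number from compound 2 to compound 3 (0.18 log units; within the scatter).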

Compound 3, half-maximal inhibitory concentration: 180 nM
For compound 3 middle estimate and measured number coincide at the digits printed, within the range that was stated.
By their numbers in this assay, from the lowest: compounds 2, 3 and 1 (each within the scatter of the next).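

In this assay a third ring at this place, on a saturated chain carbon bound to a sulfonamide nitrogen, gives two further steps (a 1.5-fold higher number from compound 2 to compound 3 (0.18 log units; within the scatter); a 1.3-fold lower number from compound 1 to compound 3 (0.11 log units; within the scatter)), so that all three exchanges among these rings now lie within the scatter. The earlier pair offered one such step; here 3,4-dichlorophenyl, with its six-membered aromatic ring of carbon only, is replaced by 2-chloro-1,3-thiazol-5-yl, a five-membered aromatic ring with 2 hetero atoms and 2 hydrogen-bond acceptors, and the reading stays within the scatter. No evidence is at hand on why these rings read alike.

On these data alone, whether an amine, a carboxylic acid or a longer chain on that carbon would move the number beyond the scatter remains open. The compounds shown also leave open what changes elsewhere in the shared core would do.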